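Lactone ring opening on the side chain of compound 3

The source may report more compounds than this note shows. Statements on the series, on what has been measured and on what is new or still open speak of the compounds shown alone.

Measured so far:
compound 1 `COC1=C(OC)[C@H](OC(C)=O)[C@H](C/C=C(\C)CC/C=C(\C)C[C@H](O)/C=C(\C)C(=O)O)[C@@H](C)C1=O` — > 30000 nM
compound 2 `COC1=C(OC)[C@H](OC(C)=O)[C@H](C/C=C(\C)CC/C=C(\C)C[C@H](O)C=C(C)C)[C@@H](C)C1=O` — 20700 nM
compound 3 `COC1=C(OC)[C@H](OC(C)=O)[C@H](C/C=C(\C)CC/C=C(\C)C[C@@H]2C[C@@H](C)C(=O)O2)[C@@H](C)C1=O` — 11300 nM

Compound 1 returns only a limit of the assay in a functional assay on A549 cells (Homo sapiens) for inhibition, read by sulforhodamine B assay, with a stated time of 48 h; a lower number here means a stronger inhibitor of growth, a higher number a weaker inhibitor of growth; its value there is > 30000 nM. Compound 2 gives 20700 nM in this assay, and compound 3 gives 11300 nM. Compound 3 thus sits at the lowest of the two numbers given, with compound 2 nearest, but the gap between them is within the scatter, so no order between the two is claimed. The step of an at least 2.6-fold lower number from compound 1 to compound 3 (0.42 log units; beyond the scatter) is the one that clears the scatter, and it rests on the limit (the limit of > 30000 nM in this assay, at which 1 of the 3 values shown sits).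

Compound 4 `COC1=C(OC)[C@H](OC(C)=O)[C@H](C/C=C(\C)CC/C=C(\C)C[C@H](O)C[C@@H](C)C(O)O)[C@@H](C)C1=O` differs from compound 3 as follows: a group of 8 heavy atoms (5 carbon, 3 oxygen; no ring) in place of a group of 7 heavy atoms (5 carbon, 2 oxygen; one five-membered non-aromatic ring with 1 hetero atom), on a saturated chain carbon bound to a double-bonded chain carbon. This reverses the direction of the change seen in an at least 2.6-fold lower number from compound 1 to compound 3 (0.42 log units; beyond the scatter), returning to an open chain with three oxygens, and the step of a 1.8-fold lower number from compound 2 to compound 3 (0.26 log units; within the scatter) shows that the ring itself made no difference beyond the scatter. The expected step is therefore upward, of modest size, a 2.2-fold higher number from compound 3 to compound 4 (0.34 log units; beyond the scatter). For compound 4 the estimate in this assay is 25000 nM, with a range from 9000 nM to 70000 nM, and a fair chance that only a limit is returned.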

Compound 4, concentration for 50% growth inhibition: 15400 nM
Compound 4: middle estimate off by 1.6-fold (0.21 log units), on the high side; measured number inside the range.
By their numbers in this assay, from the lowest: compounds 3, 4 and 2 (each within the scatter of the next). At a limit, above all of these: compound 1.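

In this assay, among the compounds shown here, putting the open chain of 8 heavy atoms in place of the five-membered ring group, on a saturated chain carbon bound to a double-bonded chain carbon, gives a 1.4-fold higher number from compound 3 to compound 4 (0.13 log units; within the scatter); the ring is therefore not required for a value in this band, a point the earlier compounds left less directly tested. The chain end of compound 4 also stays unresolved from the simpler chain end of compound 2, with a 1.3-fold lower number from compound 2 to compound 4 (0.13 log units; within the scatter), so compounds 2, 3 and 4 now form one group with no order among them. The comparison with compound 1 gives an at least 1.9-fold lower number from compound 1 to compound 4 (0.28 log units; that floor lies within the scatter), so no separation from compound 4 can be claimed, and the reading rests on a limit: the limit of > 30000 nM in this assay, at which 1 of the 4 values shown sits.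

The compounds shown leave open whether any group at this place can move the number beyond the scatter from this group of three, for instance a primary amine or a primary amide at the chain end. They also leave open whether a six-membered lactone in place of the five-membered ring would behave any differently.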